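A few compounds are considered here, and "the series" means these few. Any claim that something is new, unique, unknown or untested is made for them only; others in the source may bear on it.

Measured in a functional assay on HepG2 cells (Homo sapiens) for cytotoxicity, read by MTT assay, with a stated time of 24 h; a lower number here means a stronger inhibitor, a higher number a weaker inhibitor:
- compound 1 `COc1cc(/C=C2\CN(C)C/C(=C\c3ccccc3F)C2=O)cc(OC)c1` – 1240 nM
- compound 2 `CN1C/C(=C\c2cccc([N+](=O)[O-])c2)C(=O)/C(=C/c2ccccc2F)C1` – 1080 nM
- compound 3 `COc1cc(/C=C2\CN(C)C/C(=C\c3ccc(F)cc3)C2=O)cc(OC)c1` – 6140 nM

Compound 3 carries the highest number of the three in this assay, and its gaps to compound 1 and to compound 2 both lie beyond the scatter. Next in line is compound 4 `COc1cc(/C=C2\CN(C)C/C(=C\c3ccc(Cl)cc3)C2=O)cc(OC)c1`, which differs from compound 3 by chloro in place of fluoro on an aromatic carbon.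

Within the data shown here, one measured step touches this aryl group: a 5.0-fold higher number from compound 1 to compound 3 (0.69 log units; beyond the scatter). That step changes where the fluoro sits, not which halogen is present, so it shows that this ring can move the number but gives neither size nor direction for the exchange. Among the measured compounds shown here, no measured pair exchanges fluoro for chloro. With no evidence for a shift, only a small one is expected in this assay, with no firm direction.

The expected change is a 1.5-fold lower number from compound 3 to compound 4 (0.19 log units; within the scatter). For compound 4 the estimate is 4000 nM, with an expected range of 1400 nM to 11000 nM.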

Compound 4, half-maximal inhibitory concentration: 5950 nM
Estimate against measurement, compound 4: 1.5-fold (0.17 log units) below, and the stated range covers the measured number.
By their numbers in this assay, from the lowest: compounds 2 and 1 (each within the scatter of the next); then compounds 4 and 3 (each within the scatter of the next).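

In this assay, chloro in place of fluoro on this aromatic carbon, para to a large group, leaves the number in place: a 1.0-fold lower number from compound 3 to compound 4 (0.01 log units; within the scatter). The gap to the 2-fluorophenyl compound stays with the 4-chlorophenyl group as well, at a 4.8-fold higher number from compound 1 to compound 4 (0.68 log units; beyond the scatter), so among compounds 1, 3 and 4 the gap goes with the 2-fluorophenyl to 4-halophenyl difference and not with which of these two halogens is present. Nothing available gives a reason for either result.

Open, as far as these compounds go, is whether the number stays equally flat when this place carries a non-halogen group, such as methoxy or an amine. Among these compounds, also open is whether 2-chlorophenyl would give a number close to the one compound 1 gives, 1240 nM.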